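Swapping chloromethyl for prop-1-en-1-yl on the amide carbonyl

The source may report more compounds than this note shows. Statements on the series, on what has been measured and on what is new or still open speak of the compounds shown alone.

compound 1 `COc1ccc(CN(C(=O)C(C)Br)c2cc(OC)c(OC)c(OC)c2)cc1O` gives 160 nM
compound 2 `COc1ccc(CN(C(=O)C=C(C)C)c2cc(OC)c(OC)c(OC)c2)cc1O` gives 280 nM
compound 3 `COc1ccc(CN(C(=O)CCl)c2cc(OC)c(OC)c(OC)c2)cc1O` gives 210 nM

All three values come from a functional assay on KYSE-450 cells (Homo sapiens) for inhibition, read by MTT assay, with a stated time of 48 h (on this read-out higher numbers stand for weaker inhibition and lower numbers for stronger inhibition), and lie within the scatter of each other, so compound 3 holds no distinct rank among them. Its two steps are a 1.3-fold higher number from compound 1 to compound 3 (0.12 log units; within the scatter) and a 1.3-fold lower number from compound 2 to compound 3 (0.12 log units; within the scatter), and the remaining step is a 1.8-fold higher number from compound 1 to compound 2 (0.24 log units; within the scatter).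

Compound 4 `C/C=C/C(=O)N(Cc1ccc(OC)c(O)c1)c1cc(OC)c(OC)c(OC)c1` carries prop-1-en-1-yl in place of chloromethyl on a carbonyl carbon. The closest measured parallel is the exchange between chloromethyl and 2-methylprop-1-en-1-yl, seen in a 1.3-fold lower number from compound 2 to compound 3 (0.12 log units; within the scatter). No exchange at this carbonyl carbon has yet moved this assay beyond the scatter, so none is expected here. The expected change is a 1.1-fold higher number from compound 3 to compound 4 (0.04 log units; within the scatter), which would stay within the scatter. Compound 4 is estimated at 230 nM, with an expected range from 110 nM to 480 nM in this series.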

Compound 4, half-maximal inhibitory concentration: 67 nM
Compound 4: the middle estimate sits 3.4-fold (0.54 log units) above what was measured; measured number outside the range, below it.
By their numbers in this assay, from the lowest: compound 4; then compounds 1, 3 and 2 (each within the scatter of the next).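

In this assay, among the compounds shown here, this carbonyl carbon, whose other neighbour is the amide-type nitrogen, no longer looks indifferent to the group it carries: prop-1-en-1-yl in place of chloromethyl gives a 3.1-fold lower number from compound 3 to compound 4 (0.50 log units; beyond the scatter) and passes the scatter, which no step among compound 1, compound 2 and compound 3 did. Prop-1-en-1-yl also stands apart from the other two groups, with a 4.2-fold lower number from compound 2 to compound 4 (0.62 log units; beyond the scatter) for the exchange from 2-methylprop-1-en-1-yl and a 2.4-fold lower number from compound 1 to compound 4 (0.38 log units; beyond the scatter) for the exchange from 1-bromoethyl. A double bond outside aromatic rings is not enough on its own, as compound 2 also has one and stays within the scatter of compound 1 and compound 3.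

Nothing in the data shown accounts for these steps. From the compounds shown here alone, it remains open whether the gain is specific to prop-1-en-1-yl or extends to an ethenyl group, a saturated propyl chain, a prop-1-yn-1-yl group or a longer pent-1-en-1-yl chain.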